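Swapping carbamoyl for isopropyl on a fused aromatic core

The source may report more compounds than this note shows. Statements on the series, on what has been measured and on what is new or still open speak of the compounds shown alone.

Measured so far:
- compound 1, `Brc1ccc2ccn(CCN3CCN(C4CCCCC4)CC3)c2c1`: 36%
- compound 2, `CN1CCCN(CCn2ccc3ccc(C(N)=O)cc32)CC1`: 33%

In an assay on HEK293 cells for binding affinity to 5-hydroxytryptamine receptor 7 (Homo sapiens), read by radioligand binding, tested at 1 uM (on this read-out lower numbers stand for less inhibition and higher numbers for more inhibition at the one concentration tested (going by the name of the read-out)), compound 2 gives 33%, the lower of the two numbers recorded; compound 1 gives 36%, and the gap between the two lies within the usual scatter, so the two numbers count as level. Compound 3, `CC(C)c1ccc2ccn(CCN3CCCN(C)CC3)c2c1`, has not been tested. It differs from compound 2 in one place: isopropyl in place of carbamoyl on an aromatic carbon. Within the data shown here, no measured pair shows this exchange, so the size of its effect in this assay is unknown from the data at hand. With a single reference point, compound 3 is expected to land close to compound 2, with a small upward step plausible but no confident direction, so the expected change from compound 2 to compound 3 is a number 7 percentage points higher from compound 2 to compound 3 (within the scatter). Compound 3 is estimated at 40%, with a range from 15% to 65%.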

Compound 3, a percentage reported as inhibition, at one concentration (the size of the read-out at that concentration, not a potency): 72%
Estimate against measurement, compound 3: 32 percentage points below, and the stated range ends below it.
By their numbers in this assay, from the lowest: compounds 2 and 1 (each within the scatter of the next); then compound 3.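

In this assay, exchanging carbamoyl for isopropyl on this aromatic carbon gives a number 39 percentage points higher from compound 2 to compound 3 (beyond the scatter), so this position is not indifferent to the group it carries. The two groups have the same count of heavy atoms, yet the step is large, so heavy-atom count alone does not set the read-out here; the exchange also removes the hydrogen-bond donor and acceptor of carbamoyl and leaves only carbon in the group. No measurement at hand accounts for the size of this step.

This single pair cannot separate the loss of that donor and acceptor from the other differences between the two groups. Going by these compounds, whether a methyl group, a methoxy group or a carboxylic acid at this position would read nearer compound 2 or compound 3 remains open.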